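Side chain swaps on a shared core: what to expect

The source may hold more compounds than are shown below. What is called first, only, known or untested is meant among the compounds shown, and "the series" means these compounds.

Compound 1 `N=C(N)NCCC[C@H](NC(=O)CN(c1nc(Cl)nc2[nH]cnc12)C1CC1)C(=O)O`: 17%
Compound 2 `CC[C@H](C)[C@H](NC(=O)CN(c1nc(Cl)nc2[nH]cnc12)C1CC1)C(=O)O`: 21.4%
Compound 3 `O=C(O)CNC(=O)CN(c1nc(Cl)nc2[nH]cnc12)C1CC1`: 19.8%

Of the compounds shown here, three with the same core have been tested so far, and they differ only in the group on a saturated chain carbon bound to an amide-type nitrogen and a carbonyl carbon. In a functional assay on the whole organism (Tail, strain ICR) with Mus musculus as the target, in the tail flick test, with a stated time of 120 min, at a dose of 25 umol/kg by the oral route (a lower number here means a weaker effect, a higher number a stronger effect of the compound at the dose given), compound 1 gives 17%, compound 2 gives 21.4% and compound 3 gives 19.8%. Compound 3 sits second highest of these three numbers, but all three lie close together: a number 2.8 percentage points higher from compound 1 to compound 3 (within the scatter), a number 1.6 percentage points lower from compound 2 to compound 3 (within the scatter), and a number 4.4 percentage points higher from compound 1 to compound 2 (within the scatter). None of these steps is beyond the scatter, so the three measured compounds cannot be told apart.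

Compound 4 `O=C(O)CC[C@H](NC(=O)CN(c1nc(Cl)nc2[nH]cnc12)C1CC1)C(=O)O` is the next compound, and it differs from compound 3 by 2-carboxyethyl in place of hydrogen on a saturated chain carbon bound to an amide-type nitrogen and a carbonyl carbon. Among the measured compounds shown here, the steps that bear on this change are the two that altered the same place, the step from compound 2 to compound 3 and the step from compound 1 to compound 3, and both stayed within the scatter. The expected step is therefore a number 0.8 percentage points lower from compound 3 to compound 4 (within the scatter), that is, no change beyond the scatter. Compound 4 is estimated to give about 19% in this assay, with a likely range from 8% to 30%.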

Compound 4, a percentage reported as activity, at one dose (the size of the read-out at that dose, not a potency): 30.1%
Compound 4: the middle estimate sits 11.1 percentage points below what was measured, and the stated range ends below it.
By their numbers in this assay, from the lowest: compounds 1, 3, 2 and 4 (each within the scatter of the next, the first and the last beyond it).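

In this assay this position shows its first step beyond the scatter: putting 2-carboxyethyl in place of hydrogen gives a number 10.3 percentage points higher from compound 3 to compound 4 (beyond the scatter) and shows that the group on this saturated chain carbon can change the read-out. The change of the side chain's end group gives a number 13.1 percentage points higher from compound 1 to compound 4 (beyond the scatter) and also clears the scatter, whereas 2-carboxyethyl in place of sec-butyl gives a number 8.7 percentage points higher from compound 2 to compound 4 (within the scatter) and so does not separate these two groups. Nothing available accounts for these steps.

As far as these compounds go, what remains open is which part of 2-carboxyethyl matters, since a shorter or longer chain ending in a carboxylic acid, or a chain of the same length ending in a primary amide, would test the acid and the chain length separately. The read-out also comes from a single dose and a single time, so it leaves open whether compound 4 would stay apart from the others at other doses or times.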